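Losing the 4-aminophenyl group from compound 1

The compounds below may be only part of what the source reports. "The series", "measured", "known", "first", "only" and "open" are said of these compounds alone.

- compound 1 `COc1cc(C(=O)c2cn(-c3ccccc3)cc2-c2ccc(N)cc2)cc(OC)c1OC`: 9 nM
- compound 2 `COc1cc(C(=O)c2cn(-c3ccccc3C)cc2-c2ccccc2)cc(OC)c1OC`: 2200 nM
- compound 3 `COc1ccccc1-n1cc(C(=O)c2cc(OC)c(OC)c(OC)c2)c(-c2ccccc2)c1`: 150 nM

In a functional assay on MCF7 cells (Homo sapiens) for cytotoxicity, read by MTT assay, with a stated time of 96 h (on this read-out higher numbers stand for weaker inhibition and lower numbers for stronger inhibition), compound 1 stands lowest of the three at 9 nM, and its gaps to the other two lie beyond the scatter. Compound 4 `COc1cc(C(=O)c2cn(-c3ccccc3)cc2-c2ccccc2Br)cc(OC)c1OC` has 2-bromophenyl in place of 4-aminophenyl on an aromatic carbon.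

Among the compounds with values here, no measured step covers this exchange, and no measured compound carries 2-bromophenyl. Within the data shown here, the only measured step, methoxy in place of methyl on an aromatic carbon, is a 15-fold lower number from compound 2 to compound 3 (1.17 log units; beyond the scatter), a large step. It bears only indirectly, showing that one small exchange can move the number far. Neither compound 2 nor compound 3 carries 4-aminophenyl, and both read well above compound 1, with compound 3 at 150 nM and compound 2 at 2200 nM.

A large rise is therefore expected in this assay, and the estimated change is a 33-fold higher number from compound 1 to compound 4 (1.52 log units; beyond the scatter). The estimate for compound 4 is 300 nM, with an expected range from 50 nM to 2000 nM.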

Compound 4, half-maximal inhibitory concentration: 190 nM
Estimate against measurement, compound 4: 1.6-fold (0.20 log units) above; the measured number falls inside the stated range.
By their numbers in this assay, from the lowest: compound 1; then compounds 3 and 4 (each within the scatter of the next); then compound 2.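

In this assay, the exchange of 4-aminophenyl for 2-bromophenyl gives a 21-fold higher number from compound 1 to compound 4 (1.32 log units; beyond the scatter), the first step shown at this position, and it shows that the number here depends strongly on the group this carbon carries. The two groups match in heavy-atom count and each is one six-membered aromatic ring of carbon only, so so large a step needs no change in the size of the group. No measurement given here accounts for the step.

The exchange alters both the atom on the phenyl ring and the place it occupies, and the compounds shown do not separate these two changes. From the compounds shown here alone, it remains open how compound 1 would compare with a close analogue carrying 2-aminophenyl, 4-bromophenyl or 4-hydroxyphenyl at this position.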